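Removing the Amide Methyl in a Fused Five-Ring Series

The compounds below may be only part of what the source reports. "The series", "measured", "known", "first", "only" and "open" are said of these compounds alone.

Compound 2 `Cc1ccc([C@@H]2CN(C)[C@]3(C(=O)N(C)c4ccccc43)[C@]23Cc2ccccc2C3=O)cc1` gives 6.4% in a functional assay on the whole organism (strain Wister albino) for inhibition, with Rattus norvegicus as the target, read by paw edema, with stated times of 1 h and 3 h, at a dose of 50 mg/kg by the intraperitoneal route; a lower number here means less inhibition, a higher number more inhibition at the dose given (going by the name of the read-out). Compound 1 `Cc1ccc([C@@H]2CN(C)[C@]3(C(=O)Nc4ccccc43)[C@]23Cc2ccccc2C3=O)cc1` differs from it by hydrogen in place of methyl on an amide-type nitrogen in a ring, and in this assay compound 1 gives 27.4%; this step, a number 21 percentage points higher from compound 2 to compound 1 (beyond the scatter), is the clearest effect seen among the three measured compounds. Compound 3 `COc1ccc([C@@H]2CN(C)[C@]3(C(=O)N(C)c4ccccc43)[C@]23Cc2ccccc2C3=O)cc1` differs from compound 2 by methoxy in place of methyl on an aromatic carbon, and in this assay compound 3 gives 3.3%, a step of a number 3.1 percentage points lower from compound 2 to compound 3 (within the scatter). Compound 4 `COc1ccc([C@@H]2CN(C)[C@]3(C(=O)Nc4ccccc43)[C@]23Cc2ccccc2C3=O)cc1` has not yet been measured. It differs from compound 3 by hydrogen in place of methyl on an amide-type nitrogen in a ring, the same change, at the same place, as from compound 2 to compound 1. For the measured compounds named here, a comparable step is expected here, an estimated a number 20.7 percentage points higher from compound 3 to compound 4 (beyond the scatter) in this assay, resting on the single earlier instance a number 21 percentage points higher from compound 2 to compound 1 (beyond the scatter). Compound 4 is therefore expected to reach about 24%, most likely between 10% and 38%.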

Compound 4, a percentage reported as inhibition, in the whole organism at one dose (the size of the read-out at that dose, not a potency): 20.5%
For compound 4 the middle estimate is 3.5 percentage points above the measured one, within the range that was stated.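

Taking the methyl off the amide-type nitrogen gives a step of a number 17.2 percentage points higher from compound 3 to compound 4 (beyond the scatter) in this assay, so this change carries over between the two cores at a similar size: the same change on two cores in this assay, a number 21 percentage points higher (beyond the scatter) from compound 2 to compound 1 and a number 17.2 percentage points higher (beyond the scatter) from compound 3 to compound 4, 3.8 percentage points apart, within the scatter of two such steps

Methoxy in place of methyl on an aromatic carbon gives a step of a number 6.9 percentage points lower from compound 1 to compound 4 (within the scatter), and on both cores this second change stays within the scatter: the same change on two cores in this assay, a number 3.1 percentage points lower (within the scatter) from compound 2 to compound 3 and a number 6.9 percentage points lower (within the scatter) from compound 1 to compound 4, 3.8 percentage points apart, within the scatter of two such steps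

All this rests on just two pairs of compounds at one dose, so it does not show why the amide hydrogen gives the higher number, or whether the same step would appear on any other core.

The compounds shown carry only hydrogen or methyl on that nitrogen, and only methyl or methoxy on that aromatic carbon. On these data alone, it stays open how an ethyl group on the nitrogen, or a chlorine atom or a carboxylic acid on the aromatic carbon, would read in this assay.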